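The source may report more compounds than this note shows. Statements on the series, on what has been measured and on what is new or still open speak of the compounds shown alone.

Compound 1, `Nc1ccc(Nc2nc3ccccc3nc2S(=O)(=O)c2ccccc2)cc1`, in a functional assay on PC-3 cells (Homo sapiens) for cytotoxicity, read by MTT assay, with a stated time of 72 h (a lower number here means a stronger inhibitor, a higher number a weaker inhibitor), gives 5830 nM.
Compound 2, `COc1cc(Nc2nc3ccccc3nc2S(=O)(=O)c2ccc(C)cc2)cc(OC)c1`, in this assay gives 2940 nM.

Of these two numbers, compound 2 has the lower one, and the nearest is compound 1, whose number is higher by an amount that still lies within the usual scatter of repeated measurements, so no order between the two can be claimed.

Compound 3, `Cc1ccc(S(=O)(=O)c2nc3ccccc3nc2Nc2ccc(N)cc2)cc1`, has not yet been measured in this assay. It differs from compound 2 in one place: 4-aminophenyl in place of 3,5-dimethoxyphenyl on a nitrogen on an aromatic ring. Among the compounds with values here, no measured pair of compounds shows exactly this change, so the size of the step can only be guessed. The same 4-aminophenyl group as in compound 3 is carried, with differences elsewhere, by compound 1, whose value of 5830 nM sits close to that of compound 2. The expectation is therefore a step from compound 2 to compound 3 of roughly a 1.5-fold higher number from compound 2 to compound 3 (0.18 log units; within the scatter), that is, a slightly weaker result but not clearly beyond the scatter. Compound 3 is estimated at 4500 nM, with a plausible range from 1500 nM to 14000 nM.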

Compound 3, half-maximal inhibitory concentration: 5000 nM
Compound 3: middle estimate off by 1.1-fold (0.05 log units), on the low side; low and high end bracket the measured number.
By their numbers in this assay, from the lowest: compounds 2, 3 and 1 (each within the scatter of the next).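

The swap of 3,5-dimethoxyphenyl for 4-aminophenyl on a nitrogen on an aromatic ring, read in this assay, comes to a 1.7-fold higher number from compound 2 to compound 3 (0.23 log units; within the scatter) and so gives the first direct view of this change: the two groups cannot be told apart here, although they differ in heavy atoms and in hydrogen-bond donors and acceptors. The second change now readable, methyl in place of hydrogen on an aromatic carbon, amounts to a 1.2-fold lower number from compound 1 to compound 3 (0.07 log units; within the scatter) and likewise separates nothing, so neither single change shown moves the number clearly beyond ordinary repeat variation. No evidence is available that bears on these results.

From the compounds shown here alone, all three compounds carry a substituted phenyl ring on that nitrogen, so it remains open whether a different kind of group there, such as a plain butyl chain or a pyridine ring, would give a number clearly apart from these. Also open, going by these compounds, is whether a carboxylic acid or a hydroxyl group in place of the amine on the phenyl ring, or a chlorine in place of the methyl, would shift the number any further.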